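Halogen swap on the aromatic carbon in a hydrazone series

The source may hold more compounds than are shown below. What is called first, only, known or untested is meant among the compounds shown, and "the series" means these compounds.

Compound 3 `O=C(COc1cccc2ccccc12)N/N=C/c1ccccc1Br` carries bromo on an aromatic carbon. In an ADME assay on HEL cells (Homo sapiens) for cytotoxicity (on this read-out lower numbers stand for higher toxicity in this test and higher numbers for lower toxicity in this test), compound 3 gives >= 20 ug/mL, which is a limit of the assay rather than a number. Compound 2 `O=C(COc1cccc2ccccc12)N/N=C/c1ccccc1[N+](=O)[O-]` is the nitro analogue; in this assay compound 2 gives 20 ug/mL. Compound 1 `COc1cc(/C=N/NC(=O)COc2cccc3ccccc23)cc(OC)c1OC` gives >= 20 ug/mL in this assay, again a limit. The step of a number no lower from compound 2 to compound 3 (the limit leaves the size open) therefore has no readable size because the limit of >= 20 ug/mL in this assay, at which 2 of the 3 values shown sit, caps it.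

Compound 4 `O=C(COc1cccc2ccccc12)N/N=C/c1ccccc1Cl` differs from compound 3 by chloro in place of bromo on an aromatic carbon. Within the data shown here, only the step of a number no lower from compound 2 to compound 3 (the limit leaves the size open) bears on this position, and it gives no size. No step beyond the scatter is therefore expected in this assay; the expected step is a number no higher from compound 3 to compound 4 (the limit leaves the size open). Compound 4 is estimated at 20 ug/mL, within 10 ug/mL to 40 ug/mL.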

Compound 4, minimum cytotoxic concentration: 100 ug/mL
Beside the measured number, compound 4's estimate is 5.0-fold (0.70 log units) below it, and the stated range ends below it.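

In this assay, exchanging the nitro group for chloro gives a 5.0-fold higher number from compound 2 to compound 4 (0.70 log units; beyond the scatter). Among these compounds, this is the first readable step at this position, and it shows that a change here can move the read-out beyond the scatter. The step from bromo to chloro cannot be read, because compound 3 stands at a limit rather than a number: the limit of >= 20 ug/mL in this assay, at which 2 of the 4 values shown sit.

From the compounds shown here alone, whether bromo and chloro truly differ at this position remains open. So does the read-out with an amine or a carboxylic acid on the same aromatic carbon.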